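Cyano for Trifluoromethyl: Cytotoxicity Stays at the Limit

The compounds below may be only part of what the source reports. "The series", "measured", "known", "first", "only" and "open" are said of these compounds alone.

Measured compounds in an ADME assay on Vero cells (Chlorocebus sabaeus) for cytotoxicity, with a stated time of 72 h; on this read-out higher numbers stand for weaker inhibition and lower numbers for stronger inhibition:
- compound 1 `O=[N+]([O-])c1cn2c(n1)OC[C@@H](OCc1csc(-c3ccc(C(F)(F)F)cc3)n1)C2`: > 128000 nM
- compound 2 `N#Cc1ccc(-c2nc(CO[C@@H]3COc4nc([N+](=O)[O-])cn4C3)cs2)cc1`: > 128000 nM
- compound 3 `O=[N+]([O-])c1cn2c(n1)OC[C@@H](OCc1cn(-c3ccc(C(F)(F)F)cc3)nn1)C2`: > 128000 nM

Each of these three values is a limit of this assay and not a number. The change from compound 1 to compound 2 is cyano in place of trifluoromethyl on an aromatic carbon, and its step is a step that the two limits leave unreadable from compound 1 to compound 2. Compound 4 `N#Cc1ccc(-n2cc(CO[C@@H]3COc4nc([N+](=O)[O-])cn4C3)nn2)cc1` differs from compound 3 by cyano in place of trifluoromethyl on an aromatic carbon, the same change, since the two descriptions of the place agree word for word. The difference between the core of compound 1 and the core of compound 3 is not broken down here.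

For compound 4 a step that the limit leaves unreadable from compound 3 to compound 4 is expected in this assay, resting on (the limit of > 128000 nM in this assay, at which 3 of the 3 values shown sit). Compound 4 is therefore estimated at 150000 nM, between 90000 nM and 300000 nM, most likely again reported as a limit.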

Compound 4, half-maximal inhibitory concentration: > 128000 nM
Compound 4 gave a limit, no number; the forecaster's own chance of this, stated with the estimate: 85%; the middle value lies beyond the limit too.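

In this assay, compound 3 and compound 4 both give a limit and not a number, so no step can be read between them. The compounds shown leave open whether cyano in place of trifluoromethyl changes this read-out at all.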